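This account rests on a few compounds, and the source may have more. Where it says the series, first, only, none or still open, it means among the compounds named here.

In a functional assay on T47D cells (Homo sapiens) for cytotoxicity, read by MTT assay, with a stated time of 2 days (a lower number here means a stronger inhibitor, a higher number a weaker inhibitor), compound 1 `Cc1ccc2nc(-c3ccccc3N(C)C)[nH]c(=O)c2c1` gives 26700 nM, the higher of the two exact numbers, while compound 3 `CCN(CC)c1ccc2nc(-c3ccccc3N(C)C)[nH]c(=O)c2c1` gives 2210 nM. Compound 2 `Cc1cccc(-c2nc3cc(C)ccc3c(=O)[nH]2)c1`, which has no dimethylamino, reads > 50000 nM, a limit of the assay and not a number. Compound 4 `Cc1ccc2nc(-c3ccccc3F)[nH]c(=O)c2c1` carries fluoro in place of dimethylamino on an aromatic carbon, ortho to a large group (fluoro in place of dimethylamino on an aromatic carbon). Within the data shown here, the only measured step, a 12-fold lower number from compound 1 to compound 3 (1.08 log units; beyond the scatter), is diethylamino in place of methyl on an aromatic carbon; it leaves the dimethylamino untouched and so bears only loosely. Resting on compound 2 at > 50000 nM, a modest move to a higher number is expected in this assay. The expected step is a 1.4-fold higher number from compound 1 to compound 4 (0.15 log units; within the scatter). Compound 4 is estimated at 38000 nM, with an expected range from 15000 nM to 75000 nM.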

Compound 4, half-maximal inhibitory concentration: > 50000 nM
Compound 4 was reported as a limit (the forecaster's own chance of this, stated with the estimate: 40%); middle value at least 1.3-fold (0.11 log units) from the limit.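

In this assay, this is the only step shown that changes the dimethylamino itself: fluoro in its place on an aromatic carbon, ortho to a large group, gives an at least 1.8-fold higher number from compound 1 to compound 4 (0.27 log units; that floor lies within the scatter). Compound 4 reads > 50000 nM, a limit of the assay and not a number. The floor of the step lies within the scatter, so the change is not shown to matter, and its full size stays unread: the limit of > 50000 nM in this assay, at which 2 of the 4 values shown sit.

As far as these compounds go, it remains open whether methylamino or methoxy at this place would hold the number of compound 1. From the compounds shown here alone, it is also open whether the diethylamino of compound 3 would lower the number when paired with fluoro.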